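The source may hold more compounds than are shown below. What is called first, only, known or untested is meant among the compounds shown, and "the series" means these compounds.

Three compounds built on one shared core were examined in a functional assay on MCF7 cells (Homo sapiens) for antiproliferative activity, read by sulforhodamine B assay, with a stated time of 72 h; on this read-out lower numbers stand for stronger inhibition and higher numbers for weaker inhibition. Compound 1 `FC(F)(F)c1ccc(CN2CCN(Cc3cc(-c4ccc(OCc5ccccc5)cc4)on3)CC2)cc1` gives 2900 nM in this assay. Compound 2 `COc1ccc(COc2ccc(-c3cc(CN4CCN(Cc5ccc(C(F)(F)F)cc5)CC4)no3)cc2)cc1` gives 1300 nM in this assay. Compound 3 `COc1cc(COc2ccc(-c3cc(CN4CCN(Cc5ccc(C(F)(F)F)cc5)CC4)no3)cc2)cc(OC)c1` gives 100 nM in this assay. The change from compound 1 to compound 2 is methoxy in place of hydrogen on an aromatic carbon, and the step it made was a 2.2-fold lower number from compound 1 to compound 2 (0.35 log units; beyond the scatter). The step of a 29-fold lower number from compound 1 to compound 3 (1.46 log units; beyond the scatter) is large, and the step of a 13-fold lower number from compound 2 to compound 3 (1.11 log units; beyond the scatter) is also large. Compound 3 thus shows the lowest number of the three, with both of its steps to the others beyond the scatter.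

Compound 4 `COc1cc(COc2ccc(-c3cc(CN4CCN(Cc5ccc(C(F)(F)F)cc5)CC4)no3)cc2)cc(OC)c1OC` is not yet measured in this assay. It differs from compound 3 by methoxy in place of hydrogen on an aromatic carbon. Among the measured compounds shown here, this is the same kind of change as the one from compound 1 to compound 2, but not the same: in compound 3 the entering methoxy stands ortho to two methoxy groups (2 heavy atoms each) as well as para to a large group, whereas in compound 1 it stands only para to a large group. The two cores themselves differ by 3,5-dimethoxyphenyl in place of phenyl on a saturated chain carbon bound to an oxygen on an aromatic ring.

Compound 4 is expected to make a step of a 1.7-fold lower number from compound 3 to compound 4 (0.22 log units; within the scatter) in this assay. That expectation rests on the earlier step of a 2.2-fold lower number from compound 1 to compound 2 (0.35 log units; beyond the scatter), while the different surroundings of the place leave room for a wider outcome. Compound 4 is estimated at 60 nM in this assay, within a range from 20 nM to 200 nM.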

Compound 4, half-maximal inhibitory concentration: 1800 nM
Compound 4: the middle estimate sits 30-fold (1.48 log units) below what was measured, and the stated range ends below it.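

In this assay, the methoxy that turns 3,5-dimethoxyphenyl into 3,4,5-trimethoxyphenyl gives an 18-fold higher number from compound 3 to compound 4 (1.26 log units; beyond the scatter) and so runs against the earlier step, which shows that this change did not carry over between the two cores in either size or direction: the same change on two cores in this assay, a 2.2-fold lower number (0.35 log units; beyond the scatter) from compound 1 to compound 2 and an 18-fold higher number (1.26 log units; beyond the scatter) from compound 3 to compound 4, 40-fold (1.60 log units) apart, beyond the scatter of two such steps. The other two new steps, a 1.4-fold higher number from compound 2 to compound 4 (0.14 log units; within the scatter) and a 1.6-fold lower number from compound 1 to compound 4 (0.21 log units; within the scatter), both lie within the scatter, so the benefit held by compound 3 is gone in compound 4. Among the compounds shown here, what this does not show is why the two steps part: only two pairs are at hand, and in the second pair the entering methoxy stands ortho to two methoxy groups, yet these pairs alone cannot tie the difference to those neighbours or to any other feature of the core.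

The compounds shown leave open whether a hydroxyl group, a chlorine or an ethoxy group entering at that same place would keep the number of compound 3 at 100 nM or lose it as the methoxy does. They also leave open whether the change would behave the same way if an amine or a carboxylic acid took the place of the trifluoromethyl group.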